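The source may report more compounds than this note shows. Statements on the series, on what has been measured and on what is new or still open speak of the compounds shown alone.

Series notes. The three measured compounds share one core and differ only in the group on one aromatic carbon. Compound 1 `COc1ccc(-c2c(C)nn(-c3nc(-c4ccc(Cl)c(Cl)c4)c(SC(C)C)s3)c2C(=O)O)cc1` carries a 4-methoxyphenyl there, and in a functional assay on BJAB cells (Homo sapiens) for antiproliferative activity, with a stated time of 4 days (a higher number here means that more compound is needed for the effect, a lower number that less compound is needed), compound 1 gives 2100 nM. Compound 2 `COc1ccc(C)cc1-c1c(C)nn(-c2nc(-c3ccc(Cl)c(Cl)c3)c(SC(C)C)s2)c1C(=O)O` carries a 2-methoxy-5-methylphenyl instead; in this assay compound 2 gives 9500 nM. Compound 3 `Cc1nn(-c2nc(-c3ccc(Cl)c(Cl)c3)c(SC(C)C)s2)c(C(=O)O)c1Cc1ccccc1[N+](=O)[O-]` carries a 2-nitrobenzyl, and in this assay compound 3 gives 20000 nM, the highest number of the three, set apart from both neighbours beyond the scatter.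

Compound 4 `COc1cncc(-c2c(C)nn(-c3nc(-c4ccc(Cl)c(Cl)c4)c(SC(C)C)s3)c2C(=O)O)c1` is not yet measured. 5-methoxypyridin-3-yl in place of 2-nitrobenzyl on an aromatic carbon The entering group is, like the groups of compound 1 and compound 2, a six-membered aromatic ring bound directly to the core, whereas the leaving group of compound 3 reaches its ring through one more carbon. Among the compounds with values here, the steps that bear on this change run the other way: a 9.5-fold higher number from compound 1 to compound 3 (0.98 log units; beyond the scatter) and a 2.1-fold higher number from compound 2 to compound 3 (0.32 log units; beyond the scatter). Going back from compound 3 to a directly bound ring is therefore expected to lower the number beyond the scatter, by roughly a 5.0-fold lower number from compound 3 to compound 4 (0.70 log units; beyond the scatter). Within the data shown here, the ring nitrogen has no precedent among the three, so the estimate is kept between the numbers of compound 1 and compound 2. For compound 4 in this assay the estimate is 4000 nM, with a range from 1500 nM to 12000 nM.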

Compound 4, half-maximal effective concentration: 21000 nM
Compound 4: the middle estimate sits 5.3-fold (0.72 log units) below what was measured, outside the stated range (above it).
By their numbers in this assay, from the lowest: compound 1; then compound 2; then compounds 3 and 4 (each within the scatter of the next).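

In this assay, a six-membered aromatic ring bound directly to the core is not enough on its own to keep the number low: 5-methoxypyridin-3-yl in place of 2-nitrobenzyl gives a 1.1-fold higher number from compound 3 to compound 4 (0.02 log units; within the scatter), so the extra carbon of the leaving group does not separate these two groups here. The two carbon-only rings bound directly to the core both stand apart from the entering group, with a 10-fold higher number from compound 1 to compound 4 (1.00 log units; beyond the scatter) and a 2.2-fold higher number from compound 2 to compound 4 (0.34 log units; beyond the scatter), so this position tolerates some directly bound rings better than others, and direct attachment alone does not sort the four compounds, with compound 4 going against any such rule. Nothing among the data gives a reason for these steps.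

The compounds shown leave open whether the ring nitrogen or the way the methoxy group is placed on the ring accounts for the step from the 4-methoxyphenyl group, a question that a 6-methoxypyridin-3-yl or a plain pyridin-3-yl group would address. They also leave open how a 4-methoxybenzyl group, which would pair the ring of compound 1 with one more carbon, would compare in this position.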